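Amine substituent variation on the shared core

A few compounds are considered here, and "the series" means these few. Any claim that something is new, unique, unknown or untested is made for them only; others in the source may bear on it.

Within the data shown here, compound 1 `OCCCNc1ncnc2[nH]cc(-c3cccc(Cl)c3)c12` gives 2490 nM in an assay on HEK293T cells for displacement of a labelled ligand from Leucine-rich repeat serine/threonine-protein kinase 2 (Homo sapiens), read by NanoBRET, with a stated time of 2 h (a higher number here means a weaker inhibitor, a lower number a stronger inhibitor), the highest of the two numbers so far. Compound 2 `Clc1cccc(-c2c[nH]c3ncnc(N4CCCCC4)c23)c1` gives 1140 nM in this assay; the step of a 2.2-fold lower number from compound 1 to compound 2 (0.34 log units; beyond the scatter) came with piperidin-1-yl in place of (3-hydroxypropyl)amino on an aromatic carbon. Compound 3 `CC(CO)CN(C)c1ncnc2[nH]cc(-c3cccc(Cl)c3)c12` is not yet measured. Relative to compound 1 it carries a group of 7 heavy atoms (5 carbon, 1 nitrogen, 1 oxygen; no ring) in place of a group of 5 heavy atoms (3 carbon, 1 nitrogen, 1 oxygen; no ring), on an aromatic carbon. Among the measured compounds shown here, the only measured step that bears on this change is a 2.2-fold lower number from compound 1 to compound 2 (0.34 log units; beyond the scatter), where the (3-hydroxypropyl)amino was also replaced and the number fell modestly. For the measured compounds named here, a step of similar size, downward, is expected in this assay for compound 3, with wide uncertainty since only one comparison exists. Compound 3 is therefore estimated at 1500 nM, range 600 nM to 4000 nM, an expected step of a 1.7-fold lower number from compound 1 to compound 3 (0.22 log units; within the scatter).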

Compound 3, half-maximal inhibitory concentration: 7140 nM
The estimate for compound 3 lay 4.8-fold (0.68 log units) below the measured number; measured number outside the range, above it.
By their numbers in this assay, from the lowest: compound 2; then compound 1; then compound 3.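

In this assay, replacing the (3-hydroxypropyl)amino does not always lower the number: the change gives a 2.9-fold higher number from compound 1 to compound 3 (0.46 log units; beyond the scatter), opposite in direction to the change to piperidin-1-yl. Against that piperidin-1-yl, the open-chain group gives a 6.3-fold higher number from compound 2 to compound 3 (0.80 log units; beyond the scatter), the largest gap among the three compounds, so replacements on this aromatic carbon spread the numbers in both directions. Nothing available explains the rise or ties it to any one feature of the entering group.

Compound 3 differs from compound 1 by a whole group, so the shown compounds cannot separate the contribution of the methyl on the chain nitrogen from that of the branch in the chain. Where a morpholine ring or a dimethylamino group would fall on this carbon also stays open.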